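Pyridinylmethyl in place of methoxybenzyl on the shared core

A few compounds are considered here, and "the series" means these few. Any claim that something is new, unique, unknown or untested is made for them only; others in the source may bear on it.

Measured so far:
- compound 1, `Nc1ncnc2c(C(=O)Nc3cccc4c3c(Br)nn4Cc3ccccc3)csc12`, in a functional assay on NFS-60 cells (Mus musculus) for inhibition, with a stated time of 72 h (on this read-out lower numbers stand for stronger inhibition of growth and higher numbers for weaker inhibition of growth), compound 1 gives 1010 nM
- compound 2, `COc1ccc(Cn2nc(Br)c3c(NC(=O)c4csc5c(N)ncnc45)cccc32)cc1`, in this assay compound 2 gives 2390 nM

Within the data shown here, compound 2 stands at the highest of the two numbers in this assay, the weaker of the pair; its nearest neighbour is compound 1, the step being a 2.4-fold higher number from compound 1 to compound 2 (0.37 log units; beyond the scatter), which is the only step in the set and arises from methoxy in place of hydrogen on an aromatic carbon.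

Compound 3, `Nc1ncnc2c(C(=O)Nc3cccc4c3c(Br)nn4Cc3ccccn3)csc12`, has not yet been measured. Against compound 2 the change is pyridin-2-yl in place of 4-methoxyphenyl on a saturated chain carbon bound to an aromatic nitrogen. Among the measured compounds shown here, the one step that bears on it is the one from compound 1 to compound 2, modest and beyond the scatter, which shows that the 4-methoxyphenyl group carries a cost relative to the plain benzyl of compound 1. Nothing measured speaks to pyridin-2-yl itself. In this assay a step back toward the level of compound 1 is therefore expected for compound 3, the estimated step being a 2.0-fold lower number from compound 2 to compound 3 (0.30 log units; within the scatter), a lower number, with the pyridine part uncertain. Compound 3 is expected to give about 1200 nM, within 400 nM to 3600 nM.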

Compound 3, concentration for 50% growth inhibition: 2500 nM
The estimate for compound 3 lay 2.1-fold (0.32 log units) below the measured number; measured number inside the range.
By their numbers in this assay, from the lowest: compound 1; then compounds 2 and 3 (each within the scatter of the next).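

In this assay, the place on a saturated chain carbon bound to an aromatic nitrogen now has three readings, and pyridin-2-yl in place of 4-methoxyphenyl gives a 1.0-fold higher number from compound 2 to compound 3 (0.02 log units; within the scatter), so these two groups cannot be told apart on this read-out, although one has a carbon-only ring and the other a ring with a hetero atom. Against the phenyl of compound 1, pyridin-2-yl gives a 2.5-fold higher number from compound 1 to compound 3 (0.39 log units; beyond the scatter), which puts a second, differently built group on the same side of compound 1 as 4-methoxyphenyl, so among these three compounds the loss is not confined to the methoxy-bearing ring. No measurement at hand accounts for either step. 

From the compounds shown here alone, it remains open whether any group at this place can give a lower number than the phenyl of compound 1, for instance a carboxylic acid, an amine such as aminomethyl, or a longer chain such as phenethyl. Going by these compounds, it also remains open whether the other pyridinyl attachments would read like pyridin-2-yl.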